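Two hydroxyphenyl swaps on a shared pyridine-type core

This account rests on a few compounds, and the source may have more. Where it says the series, first, only, none or still open, it means among the compounds named here.

Compound 1 `Oc1cccc(-c2cc(-c3cccc(C(F)(F)F)c3)cc(-c3ccccc3O)n2)c1`: 6460 nM
Compound 2 `Oc1ccc(-c2cc(-c3cccc(C(F)(F)F)c3)cc(-c3ccccc3O)n2)cc1`: > 50000 nM
Compound 3 `Oc1cccc(-c2cc(-c3cccc(OC(F)(F)F)c3)cc(-c3ccccc3O)n2)c1`: 2740 nM

In a functional assay on HCT-15 cells (Homo sapiens) for inhibition (on this read-out higher numbers stand for weaker inhibition and lower numbers for stronger inhibition), compound 1 gives 6460 nM. For compound 2 the assay returns only a limit, > 50000 nM. The change 4-hydroxyphenyl in place of 3-hydroxyphenyl on an aromatic carbon therefore produced an at least 7.7-fold higher number from compound 1 to compound 2 (0.88 log units; beyond the scatter). Compound 3 differs from compound 1 by trifluoromethoxy in place of trifluoromethyl on an aromatic carbon, which produced a 2.4-fold lower number from compound 1 to compound 3 (0.37 log units; beyond the scatter), so in this assay compound 3 gives 2740 nM.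

Compound 4 `Oc1ccc(-c2cc(-c3cccc(OC(F)(F)F)c3)cc(-c3ccccc3O)n2)cc1` is not yet measured. It differs from compound 3 by 4-hydroxyphenyl in place of 3-hydroxyphenyl on an aromatic carbon, the same kind of change as that from compound 1 to compound 2, though there the place is described as meta to a 3-(trifluoromethyl)phenyl group rather than meta to a large group. If it behaves alike, a step of about an 11-fold higher number from compound 3 to compound 4 (1.04 log units; beyond the scatter) is expected, resting on compound 1 with 6460 nM and an at least 7.7-fold higher number from compound 1 to compound 2 (0.88 log units; beyond the scatter). Compound 4 is therefore estimated at 30000 nM, with a real chance that only a limit is reported.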

Compound 4, half-maximal inhibitory concentration: > 50000 nM
Compound 4 was reported as a limit; the forecaster's own chance of this, stated with the estimate: 45%; middle value at least 1.6-fold (0.22 log units) away from the limit.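

Putting 4-hydroxyphenyl in place of 3-hydroxyphenyl again weakens inhibition in this assay, with an at least 18-fold higher number from compound 3 to compound 4 (1.26 log units; beyond the scatter). The direction of the change therefore carries over between the trifluoromethyl and trifluoromethoxy cores, but its size cannot be compared: the same change on two cores in this assay, an at least 7.7-fold higher number (0.88 log units; beyond the scatter) from compound 1 to compound 2 and an at least 18-fold higher number (1.26 log units; beyond the scatter) from compound 3 to compound 4; the limit leaves it open whether they differ The step from compound 2 to compound 4 cannot be read, so these compounds do not show whether trifluoromethoxy still lowers the number once 4-hydroxyphenyl is present: the limit of > 50000 nM in this assay, at which 2 of the 4 values shown sit.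

The compounds shown leave open how an amine or a carboxylic acid in place of the hydroxyl on 3-hydroxyphenyl would compare. They also leave open what happens when the 2-hydroxyphenyl group, the same in all four compounds, is changed.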